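The source may hold more compounds than are shown below. What is called first, only, known or untested is meant among the compounds shown, and "the series" means these compounds.

Compound 1 `CCOc1cc(NC(=O)C2(NC(=O)c3ccc4c(C5CCCC5)c(-c5ncc(Cl)cn5)n(C)c4c3)CCC2)ccc1/C=C/C(=O)OC(=O)C[C@H](O)C(=O)O`: in an ADME assay (liver) for pharmacokinetics, with Liver microsome (Homo sapiens) as the target, using microsomes (a higher number here means that the compound lasts longer, a lower number that the compound disappears faster), compound 1 gives 5.57 h.
Compound 2 `CCOc1cc(NC(=O)C2(NC(=O)c3ccc4c(C5CCCC5)c(-c5ncc(Cl)cn5)n(C)c4c3)CCC2)ccc1/C=C/C(=O)OCC(Cl)(Cl)Cl`: in this assay compound 2 reaches only the limit > 5 h, a limit of the assay rather than a number.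
Compound 3 `CCOc1cc(NC(=O)C2(NC(=O)c3ccc4c(C5CCCC5)c(-c5ncc(Cl)cn5)n(C)c4c3)CCC2)ccc1/C=C/C(=O)OCc1ccccc1`: in this assay compound 3 likewise reaches only the limit > 5 h, again a limit and not a number.

Compound 2 thus stands at a limit, and one further value shown is also a limit; only compound 1 carries a number. The steps from compound 1, a step that the limit leaves unreadable from compound 1 to compound 2 and a step that the limit leaves unreadable from compound 1 to compound 3, and the step that the two limits leave unreadable from compound 2 to compound 3 are all unreadable in size, as the limit of > 5 h in this assay, at which 2 of the 3 values shown sit, holds two of the three values. Among these three compounds, varying the group on an oxygen next to a carbonyl group has not moved the read-out to anything that can be read.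

Compound 4 `CCOc1cc(NC(=O)C2(NC(=O)c3ccc4c(C5CCCC5)c(-c5ncc(Cl)cn5)n(C)c4c3)CCC2)ccc1/C=C/C(=O)OCC(=O)N1CCOCC1` differs from compound 2 as follows: (morpholin-4-yl)carbonyl in place of trichloromethyl on a saturated chain carbon bound to an oxygen next to a carbonyl group. The step between compound 2 and compound 3, which also exchanges the group on this saturated chain carbon, bears on this change but gives no size. Among the compounds with values here, no measured step therefore points in either direction, and the expectation is no step beyond the scatter, with compound 4 expected to sit near the limit and most likely reported once more as a limit. Compound 4 is estimated at 5.5 h, range 2.5 h to 12 h. The expected step is a step that the limit leaves unreadable from compound 2 to compound 4.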

Compound 4, half-life: 0.667 h
Compound 4: middle estimate off by 8.2-fold (0.92 log units), on the high side; measured number outside the range, below it.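

Exchange on a saturated chain carbon bound to an oxygen next to a carbonyl group now shows a readable effect in this assay: (morpholin-4-yl)carbonyl in place of trichloromethyl gives an at least 7.4-fold lower number from compound 2 to compound 4 (0.87 log units; beyond the scatter), and in place of phenyl it gives an at least 7.4-fold lower number from compound 3 to compound 4 (0.87 log units; beyond the scatter). Against compound 1, the only earlier compound with a number rather than a limit, the change gives an 8.4-fold lower number from compound 1 to compound 4 (0.92 log units; beyond the scatter), the first step in these notes with a fully readable size. The steps among compound 1, compound 2 and compound 3 still cannot be read, and the two steps from compound 2 and compound 3 to compound 4 have no upper bound on their size: the limit of > 5 h in this assay, at which 2 of the 4 values shown sit.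

The compounds shown leave open whether the lower number belongs to the carbonyl of the entering group or to its six-membered ring, as only (morpholin-4-yl)carbonyl stands here. A (piperidin-1-yl)carbonyl, a dimethylaminocarbonyl or a plain methyl on the same saturated chain carbon would separate these two parts, and a number for compound 2 or compound 3 would fix the true size of the steps.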